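From butyl to piperazin-1-yl

The source may hold more compounds than are shown below. What is called first, only, known or untested is meant among the compounds shown, and "the series" means these compounds.

Going by the values given here, in a functional assay on U-251 cells (Homo sapiens) for inhibition, read by sulforhodamine B assay, with a stated time of 72 h (a lower number here means that less compound is needed, a higher number that more compound is needed for the effect), compound 1 `CCCCc1ccc(C(=O)/C=C/c2ccc([N+](=O)[O-])o2)cc1` gives 3900 nM, the lower of the two numbers so far, while compound 2 `O=C(/C=C/c1ccc([N+](=O)[O-])o1)c1ccc(-c2ccccc2)cc1` gives 24600 nM. Compound 3 `O=C(/C=C/c1ccc([N+](=O)[O-])o1)c1ccc(N2CCNCC2)cc1` keeps the core of compound 1 but differs from it in one place: piperazin-1-yl in place of butyl on an aromatic carbon. Among the compounds with values here, only one measured step bears on this place: phenyl in place of butyl gave a 6.3-fold higher number from compound 1 to compound 2 (0.80 log units; beyond the scatter). That single modest step is thin evidence, so a step of similar or smaller size towards a higher number is expected. For compound 3 the estimated value is 8000 nM, with an expected range of 2000 nM to 30000 nM. The expected change is a 2.1-fold higher number from compound 1 to compound 3 (0.31 log units; beyond the scatter).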

Compound 3, half-maximal effective concentration: 16700 nM
The estimate for compound 3 lay 2.1-fold (0.32 log units) below the measured number, and the stated range covers the measured number.
By their numbers in this assay, from the lowest: compound 1; then compounds 3 and 2 (each within the scatter of the next).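

In this assay, a second ring in place of butyl again raises the number, with a 4.3-fold higher number from compound 1 to compound 3 (0.63 log units; beyond the scatter) on this position. The non-aromatic piperazin-1-yl ring, which carries nitrogen, and the all-carbon phenyl ring cannot be told apart here, with a 1.5-fold lower number from compound 2 to compound 3 (0.17 log units; within the scatter) for the swap between them. No measurement on hand explains why butyl gives the lowest number.

Still open, going by these compounds, is whether a longer chain such as hexyl, or an open-chain amine such as dimethylamino, would stay near compound 1 or follow the two ring compounds.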